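Cyanophenyl for methoxyphenyl, tested on a second core

The source may report more compounds than this note shows. Statements on the series, on what has been measured and on what is new or still open speak of the compounds shown alone.

Compound 1 `COc1ccc(-c2ccc(CN(CC(=O)C(C)(C)O)C(=O)NC3CCN(Cc4ccc(C)cc4)CC3)cc2)cc1` reaches only a limit in an in vitro functional assay on HEK293 cells for antagonist activity at melanin-concentrating hormone receptor 1 (Homo sapiens), read by GTPgammaS binding, with a stated time of 45 min (on this read-out higher numbers stand for weaker inhibition and lower numbers for stronger inhibition), giving > 10000 nM, which is a limit rather than a number (the limit of > 10000 nM in this assay, at which 1 of the 3 values shown sits). Compound 2 `Cc1ccc(CN2CCC(NC(=O)N(CC(=O)C(C)(C)O)Cc3ccc(-c4cccc(C#N)c4)cc3)CC2)cc1` gives 5000 nM in this assay; the change here is 3-cyanophenyl in place of 4-methoxyphenyl on an aromatic carbon, and it produced an at least 2.0-fold lower number from compound 1 to compound 2 (0.30 log units; that floor lies within the scatter). Compound 3 `COc1ccc(-c2ccc(CN(CCC3CCN(Cc4ccc(C)cc4)CC3)C(=O)NC(C)C)cc2)cc1` gives 467 nM in this assay, the lowest of the two numbers. How the core of compound 3 differs from the core of compound 1 is not broken down here. Compound 4 `Cc1ccc(CN2CCC(CCN(Cc3ccc(-c4cccc(C#N)c4)cc3)C(=O)NC(C)C)CC2)cc1` carries the same change on the other core, (3-cyanophenyl in place of 4-methoxyphenyl on an aromatic carbon), with the place described in the same words. The earlier step rests on a limit, so only a modest lowering is expected in this assay, a 1.9-fold lower number from compound 3 to compound 4 (0.27 log units; within the scatter). Compound 4 is therefore estimated at 250 nM, expected to lie between 80 nM and 700 nM.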

Compound 4, antagonist equilibrium constant: 1010 nM
The estimate for compound 4 lay 4.0-fold (0.61 log units) below the measured number; the whole stated range lies below it.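

In this assay, 3-cyanophenyl in place of 4-methoxyphenyl gives a 2.2-fold higher number from compound 3 to compound 4 (0.34 log units; beyond the scatter), so the change does not carry over from one core to the other with the same outcome: the same change on two cores in this assay, an at least 2.0-fold lower number (0.30 log units; that floor lies within the scatter) from compound 1 to compound 2 and a 2.2-fold higher number (0.34 log units; beyond the scatter) from compound 3 to compound 4, at least 4.3-fold (0.63 log units) apart, beyond the scatter of two such steps

The earlier step starts from compound 1, whose value is a limit and not a number: the limit of > 10000 nM in this assay, at which 1 of the 4 values shown sits.

These two pairs show only that the outcome of this change differs between two cores; they do not show which part of the core sets the difference, or how the change would behave on any further core.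

The compounds shown leave open how an unsubstituted phenyl or a pyridyl group would read in this place on either core. They also do not separate the gain of the nitrile from the loss of the methoxy group.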